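Cyclohexyl in Place of Ethyl on the Triazole Core

The source may report more compounds than this note shows. Statements on the series, on what has been measured and on what is new or still open speak of the compounds shown alone.

Measured compounds:
compound 1, `CCc1nnn(Cc2ccc(C(F)(F)F)cc2)c1C(=O)N[C@@H](C)c1ccc(C(=O)O)cc1`, > 10000 nM
compound 2, `COc1ccc(Cn2nnc(-c3ccccc3)c2C(=O)N[C@@H](C)c2ccc(C(=O)O)cc2)cc1F`, 29.8 nM

The two measured compounds share the acid-bearing amide side chain and the five-membered aromatic ring with three nitrogens. In a functional assay on CHO cells for antagonist activity at prostaglandin E2 receptor EP4 subtype (Homo sapiens), read by calcium flux, with a stated time of 15 min (on this read-out lower numbers stand for stronger inhibition and higher numbers for weaker inhibition), compound 1 gives > 10000 nM, and this is a limit of the assay rather than a number. Compound 1 thus stands at the limit of > 10000 nM in this assay, at which 1 of the 2 values shown sits, with no measured value to place it more closely. Compound 2 carries a phenyl on the ring carbon and a different benzyl group on the ring nitrogen, and in this assay compound 2 gives 29.8 nM; the two compounds differ in more than one place, so the two values cannot be tied to any single change.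

Compound 3, `C[C@H](NC(=O)c1c(C2CCCCC2)nnn1Cc1ccc(C(F)(F)F)cc1)c1ccc(C(=O)O)cc1`, differs from compound 1 by cyclohexyl in place of ethyl on an aromatic carbon. Going by the values given here, no step between measured compounds shows this change alone. With compound 1 sitting at a limit, any gain can only be expected toward a measurable number; compound 3 is estimated at 1500 nM, in the range 200 nM to 10000 nM, which means an expected step of an at least 6.6-fold lower number from compound 1 to compound 3 (0.82 log units; beyond the scatter).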

Compound 3, half-maximal inhibitory concentration: 161 nM
Compound 3: middle estimate off by 9.3-fold (0.97 log units), on the high side; the whole stated range lies above it.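

Within this assay, cyclohexyl in place of ethyl on an aromatic carbon is the first single change shown at this position, and it brings an at least 62-fold lower number from compound 1 to compound 3 (1.79 log units; beyond the scatter) with the rest of the molecule held the same. The position, on an aromatic carbon of the five-membered ring and next to the ring nitrogen, therefore accepts a six-membered non-aromatic ring of carbon only, and with that ring in place the series moves from no measurable number to a measured one. Compound 1 stands at a limit of the assay and not at a number, so the full size of this step remains unknown: the limit of > 10000 nM in this assay, at which 1 of the 3 values shown sits.

The compounds shown do not tell whether the gain follows the ring itself or simply the larger carbon group, which an open hexyl chain, a smaller cyclopropyl ring or a tetrahydropyranyl ring with its ring oxygen would separate. They also leave open whether cyclohexyl gives a step of this size when the trifluoromethyl on the benzyl group is replaced by another group, such as a methoxy or a fluorine.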